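The compounds below may be only part of what the source reports. "The series", "measured", "known", "first", "only" and "open" are said of these compounds alone.

Measured so far in a functional assay on HT-29 cells (Homo sapiens) for inhibition, read by MTT assay, with a stated time of 72 h; a lower number here means a stronger inhibitor, a higher number a weaker inhibitor:
- compound 1 `COc1ccc(CCCNCc2c(OC)cc(Oc3ccc(Nc4ccccc4)cc3)cc2OC)cc1`: 6890 nM
- compound 2 `COc1cc(Oc2cccc(Nc3ccccc3)c2)cc(OC)c1CNCc1ccc(C)cc1`: 3880 nM
- compound 3 `COc1ccc([C@@H](C)NCc2c(OC)cc(Oc3cccc(Nc4ccccc4)c3)c(OC)c2OC)cc1`: 1630 nM

Compound 2 stands within the scatter of compound 1, while compound 3 gives a lower number, beyond the scatter.

Next in line is compound 4 `COc1cc(Oc2cccc(Nc3ccccc3)c2)cc(OC)c1CN(C)C`, which is still unmeasured. Its difference from compound 2 is dimethylamino in place of (4-methylbenzyl)amino on a saturated chain carbon bound to an aromatic carbon, with dimethylamino in place of (4-methylbenzyl)amino on a saturated chain carbon bound to an aromatic carbon.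

Going by the values given here, no measured pair isolates this change. All three measured compounds keep a ring on the amine side, so none shows what losing it does. Among the compounds with values here, their numbers run from compound 3 at 1630 nM to compound 1 at 6890 nM, and that span is the only guide. A small step towards a higher number is expected in this assay, probably within the scatter.

Expected step: a 1.5-fold higher number from compound 2 to compound 4 (0.19 log units; within the scatter).

For compound 4 the estimated value is 6000 nM, with an expected range of 2000 nM to 20000 nM.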

Compound 4, half-maximal inhibitory concentration: > 20000 nM
Compound 4: a limit, no number (the forecaster's own chance of this, stated with the estimate: 15%); at least 3.3-fold (0.52 log units) between middle value and limit.
By their numbers in this assay, from the lowest: compound 3; then compounds 2 and 1 (each within the scatter of the next). At a limit, above all of these: compound 4.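

In this assay, dimethylamino in place of (4-methylbenzyl)amino on a saturated chain carbon bound to an aromatic carbon gives an at least 5.1-fold higher number from compound 2 to compound 4 (0.71 log units; beyond the scatter), so this position does not tolerate every amine substituent in this series. Compound 4 gives > 20000 nM, which is a limit of the assay and not a number. The step therefore fixes a direction and a minimum size, while its full size stays unknown: the limit of > 20000 nM in this assay, at which 1 of the 4 values shown sits.

The change removes the aromatic ring and the amine hydrogen together, so the compounds shown cannot tell which of the two accounts for the step. A methylamino group, which keeps the hydrogen without the ring, and a tertiary N-methyl-(4-methylbenzyl)amino group, which keeps the ring without the hydrogen, would separate the two at this position.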